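The source may hold more compounds than are shown below. What is called first, only, known or untested is meant among the compounds shown, and "the series" means these compounds.

Measured so far in an ADME assay on BJ cells (Homo sapiens) for cytotoxicity, with a stated time of 72 h; on this read-out higher numbers stand for an effect only at larger amounts of compound and lower numbers for an effect already at smaller amounts:
- compound 1 `COc1ccc(-c2nc3c(c(C)nn3-c3ccccc3)c(-c3ccccc3O)c2C#N)cc1`: > 23000 nM
- compound 2 `CCc1ccc(-c2nc3c(c(C)nn3-c3ccccc3)c(-c3ccccc3F)c2C#N)cc1`: > 20000 nM
- compound 3 `C#Cc1ccccc1-c1c(C#N)c(-c2ccc(CC)cc2)nc2c1c(C)nn2-c1ccccc1`: > 20000 nM

All three values are limits, not numbers. Compound 1 stands at one of these limits, (the limit of > 23000 nM in this assay, at which 1 of the 3 values shown sits); the other two sit at the limit of > 20000 nM in this assay, at which 2 of the 3 values shown sit.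

The next compound is compound 4 `Cc1ccc(-c2nc3c(c(C)nn3-c3ccccc3)c(-c3ccccc3O)c2C#N)cc1`, which carries methyl in place of methoxy on an aromatic carbon, para to a large group, so that 4-methoxyphenyl becomes 4-methylphenyl: methyl in place of methoxy on an aromatic carbon.

Among the compounds with values here, the only measured change in a single place is a step that the two limits leave unreadable from compound 2 to compound 3. It concerns ethynyl in place of fluoro, a different change, and no size can be read from it. Within the data shown here, no measured step therefore gives a size or direction for this change, and no step beyond the scatter is expected in this assay. This expectation rests on compound 1 at > 23000 nM, a limit.

The expected step is a number no higher from compound 1 to compound 4 (the limit leaves the size open). Another limit rather than a number is the likely report. For compound 4 the estimate is 23000 nM, with an expected range of 10000 nM to 50000 nM.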

Compound 4, half-maximal effective concentration: 22200 nM
Compound 4: middle estimate off by 1.0-fold (0.02 log units), on the high side; the range from low to high includes it.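

In this assay, within the data shown here, compound 4 gives the first number of the series, whereas compound 1, compound 2 and compound 3 are reported only as limits. Methyl in place of methoxy on an aromatic carbon, para to a large group, reads as an at least 1.0-fold lower number from compound 1 to compound 4 (0.01 log units; that floor lies within the scatter) and gives only a floor, so no change beyond the scatter can be claimed for 4-methoxyphenyl to 4-methylphenyl. As far as these compounds go, the true size of this step stays open because compound 1 sits at a limit: the limit of > 23000 nM in this assay, at which 1 of the 4 values shown sits.

How far the number for compound 4 lies from the unknown value of compound 1 remains unresolved. Also open, from the compounds shown here alone, is what a different group at this place, such as an amine, a carboxylic acid or a longer chain, would give on the same core.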